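The compounds below may be only part of what the source reports. "The series", "measured", "known", "first", "only" and "open" are said of these compounds alone.

Compound 1 `CCCOc1ccc(C(=O)Nc2cccc(C)n2)cc1` carries methyl on an aromatic carbon of the shared core, and in an in vitro assay on HEK-tsA201 cells for antagonist activity at Neuronal acetylcholine receptor; alpha4/beta2 (Homo sapiens), read by fluorescence and calcium flux (a lower number here means a stronger inhibitor, a higher number a weaker inhibitor), compound 1 gives 7500 nM. Compound 2 `CCCOc1ccc(C(=O)Nc2cccc(Cl)n2)cc1` has chloro in place of methyl on an aromatic carbon. In this assay compound 2 gives only a limit, > 100000 nM. Compound 3 `CCCCNc1cccc(NC(=O)c2ccc(OCCC)cc2)n1` has butylamino in place of methyl on an aromatic carbon; in this assay compound 3 gives 54100 nM, the highest of the two numbers, and the step of a 7.2-fold higher number from compound 1 to compound 3 (0.86 log units; beyond the scatter) lies beyond the scatter, whereas an at least 1.8-fold lower number from compound 2 to compound 3 (0.26 log units; that floor lies within the scatter).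

Compound 4 `CCCOc1ccc(C(=O)Nc2cccc(Nc3ccccc3)n2)cc1` differs from compound 3 by phenyl in place of butyl on a nitrogen on an aromatic ring. For the measured compounds named here, none of the measured steps touches the group on a nitrogen on an aromatic ring: all three exchange the group on the aromatic carbon, with an at least 13-fold higher number from compound 1 to compound 2 (1.12 log units; beyond the scatter) the largest of them. Going by the values given here, no measured step therefore bears directly on phenyl in place of butyl, and neither size nor direction can be read from the numbers. The step expected is a 1.1-fold lower number from compound 3 to compound 4 (0.03 log units; within the scatter), nothing beyond the scatter. Compound 4 is thus estimated at 50000 nM, between 15000 nM and 150000 nM.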

Compound 4, half-maximal inhibitory concentration: > 100000 nM
Compound 4: only a limit was reported (the forecaster's own chance of this, stated with the estimate: 30%); middle value at least 2.0-fold (0.30 log units) from the limit.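

In this assay compound 4 gives only a limit, > 100000 nM. The step to phenyl on the nitrogen, an at least 1.8-fold higher number from compound 3 to compound 4 (0.26 log units; that floor lies within the scatter), has a floor within the scatter and so does not separate anilino from butylamino, but the comparison with methyl, an at least 13-fold higher number from compound 1 to compound 4 (1.12 log units; beyond the scatter), makes anilino the third group on this aromatic carbon to lie beyond the scatter from methyl, leaving compound 1 the strongest inhibitor of the four shown. The step between compound 2 and compound 4 cannot be read, as both stand at the same limit: the limit of > 100000 nM in this assay, at which 2 of the 4 values shown sit.

Whether any group on this aromatic carbon gives a lower number than methyl stays open, with ethyl, methoxy and a plain amine among the groups not shown. Also open, from the compounds shown here alone, is how a shorter chain on the nitrogen, such as methyl or ethyl, would compare with butyl.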